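Removing a chloro group from compound 2

The source may report more compounds than this note shows. Statements on the series, on what has been measured and on what is new or still open speak of the compounds shown alone.

Of the compounds shown here, three share a core and have been measured in an assay on cells for displacement of a labelled ligand from adenosine receptor A2b (Homo sapiens), read by scintillation counting and radioligand binding, with a stated time of 30 min, tested at 10 uM; a higher number here means more inhibition at the concentration tested (going by the name of the read-out), a lower number less inhibition. Compound 1 `CN1CCN(c2nc(-c3ccc(Cl)c(Cl)c3)nc3[nH]cnc23)CC1` gives 24.1%, compound 3 `CN1CCN(c2nc(-c3cccc(Cl)c3)nc3c2ncn3C)CC1` gives 19.2%, and compound 2 `Clc1ccc(-c2nc(N3CCCCC3)c3nc[nH]c3n2)cc1Cl` gives 0.7%, the lowest of the three numbers. Going by the values given here, the one step between compounds that differ in a single place is a number 23.4 percentage points lower from compound 1 to compound 2 (beyond the scatter), where piperidin-1-yl replaces 4-methylpiperazin-1-yl on an aromatic carbon.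

Compound 4 `Clc1cccc(-c2nc(N3CCCCC3)c3nc[nH]c3n2)c1` has not yet been measured. It differs from compound 2 by hydrogen in place of chloro on an aromatic carbon, on an aromatic carbon of a six-membered aromatic ring of carbon only, ortho to the remaining chloro group and para to a large group. Among the compounds with values here, no measured step bears on this change: compound 1 and compound 3 differ from each other in two places, so the value of compound 1 at 24.1% and that of compound 3 at 19.2% only show that both sit in the same region.

Compound 2 lies near the floor of the read-out, so a fall cannot be large, and nothing shown points to a rise. Compound 4 is therefore expected to give 3%, between -8% and 15%, a step of a number 2.3 percentage points higher from compound 2 to compound 4 (within the scatter) that stays within the scatter.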

Compound 4, a percentage reported as inhibition, at one concentration (the size of the read-out at that concentration, not a potency): > 80%
Compound 4: only a limit was reported; the forecaster's own chance of this, stated with the estimate: 0%; middle value at least 77 percentage points from the limit.
By their numbers in this assay, from the lowest: compound 2; then compounds 3 and 1 (each within the scatter of the next). At a limit, above all of these: compound 4.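

In this assay, hydrogen in place of chloro on an aromatic carbon, ortho to the remaining chloro group and para to a large group, gives a number at least 79.3 percentage points higher from compound 2 to compound 4 (beyond the scatter). Going by these compounds alone, the only earlier step concerned the other substituent on the shared core, piperidin-1-yl against 4-methylpiperazin-1-yl, so this is the first evidence that a single chloro group on the six-membered aromatic ring of carbon only can separate a read-out near the floor from one far up the scale, with piperidin-1-yl held constant. The result for compound 4 is a limit and not a number: the limit of > 80% in this assay, at which 1 of the 4 values shown sits.

Compound 1 and compound 3 differ from each other in two places, so they leave open whether the same change would have a comparable outcome with 4-methylpiperazin-1-yl in place of piperidin-1-yl. Going by these compounds, it also remains open whether another group on this carbon, such as a methoxy group, an amine or a carboxylic acid, would give a result closer to that of hydrogen or to that of chloro.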